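The compounds below may be only part of what the source reports. "The series", "measured", "known", "first", "only" and "open" are said of these compounds alone.

Compound 2 `O=C(NCc1ccccc1)c1cnc(-c2ccccc2)nc1` gives the lowest number among the three compounds measured in an assay on isolated protein for inhibition of Hematopoietic prostaglandin D synthase (Homo sapiens), read by ELISA (a higher number here means a weaker inhibitor, a lower number a stronger inhibitor), with compound 2 at 23.9 nM. Compound 1 `O=C(NCc1ccccc1)c1cnc(-c2ccccn2)nc1` stands closest, and in this assay compound 1 gives 35.7 nM; the step of a 1.5-fold lower number from compound 1 to compound 2 (0.17 log units; within the scatter) is too small to call a real difference. Compound 3 `CC(C)(O)c1nc(-c2cccc(CNC(=O)c3ccc(-c4ccccn4)nc3)c2)no1` lies furthest away, and in this assay compound 3 gives 328 nM.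

Compound 4 `CC(C)(O)c1nc(-c2cccc(CNC(=O)c3cnc(-c4ccccc4)nc3)c2)no1` has not yet been measured. It differs from compound 2 in one place: 5-(1-hydroxy-1-methylethyl)-1,2,4-oxadiazol-3-yl in place of hydrogen on an aromatic carbon. Within the data shown here, no measured step tests exactly this change. The closest comparison is between compound 1 and compound 3, which differ both in the shared core and in carrying the same 5-(1-hydroxy-1-methylethyl)-1,2,4-oxadiazol-3-yl group, and there the number rises clearly. On that basis compound 4 is expected to give a higher number than compound 2, a step of about an 8.4-fold higher number from compound 2 to compound 4 (0.92 log units; beyond the scatter). The estimate for compound 4 is 200 nM, with a range from 60 nM to 650 nM.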

Compound 4, half-maximal inhibitory concentration: 9.86 nM
The estimate for compound 4 lay 20-fold (1.31 log units) above the measured number; measured number below the stated range.
By their numbers in this assay, from the lowest: compound 4; then compounds 2 and 1 (each within the scatter of the next); then compound 3.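

In this assay, placing 5-(1-hydroxy-1-methylethyl)-1,2,4-oxadiazol-3-yl on an aromatic carbon of the six-membered aromatic ring of carbon only, meta to a large group, gives a 2.4-fold lower number from compound 2 to compound 4 (0.38 log units; beyond the scatter). This single-place change shows that the position accepts a group of this size and the number still falls modestly, something compound 3 could not show, since it differs from compound 1 in more than one place. Nothing available here explains why the number falls.

The compounds shown leave open whether a smaller group at this position, such as an amine or a carboxylic acid, would do as well, and whether the hydroxyl of the added group matters, which a plain methyl on the oxadiazole would test. On these data alone, it also remains open whether the same step holds on the core of compound 1, with pyridin-2-yl in place of phenyl.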